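The source may report more compounds than this note shows. Statements on the series, on what has been measured and on what is new or still open speak of the compounds shown alone.

Working notes on the series in an ADME assay on Raji cells (Homo sapiens) for cytotoxicity, read by CellTiter-Glo and resazurin assay, with a stated time of 72 h; on this read-out lower numbers stand for an effect already at smaller amounts and higher numbers for an effect only at larger amounts of compound.

Compound 3 `CCOC(=O)CCCCCOc1cccc(CN(C(=O)c2ccc(-c3ccc4c(c3)OCCO4)cc2)C(C)C)c1` stands only at a limit in this assay: compound 3 gives > 24400 nM, which is a limit and not a number. The two other members of the series stand at limits as well. Compound 1 `CCOC(=O)CCCCCOc1cccc(CN(C(=O)c2ccc(-c3ccncc3)cc2)C(C)C)c1` gives > 26000 nM in this assay, a limit. Compound 2 `CCOC(=O)CCCCCOc1cccc(CN(C(=O)c2ccc(-c3cnc(OC)nc3OC)cc2)C(C)C)c1` gives > 26000 nM in this assay, likewise a limit. Within the data shown here, the steps a step that the two limits leave unreadable from compound 1 to compound 2, a step that the two limits leave unreadable from compound 1 to compound 3 and a step that the two limits leave unreadable from compound 2 to compound 3 therefore cannot be read in size or direction, as the limits the limit of > 24400 nM in this assay, at which 1 of the 3 values shown sits, and the limit of > 26000 nM in this assay, at which 2 of the 3 values shown sit, show; the series so far gives no readable change.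

Compound 4 `CCOC(=O)CCCCCOc1cccc(CN(C(=O)c2ccc(-c3cccc(S(C)(=O)=O)c3)cc2)C(C)C)c1` is not yet measured in this assay. Its change from compound 3 is 3-(methylsulfonyl)phenyl in place of 2,3-dihydro-1,4-benzodioxin-6-yl on an aromatic carbon. Among the measured compounds shown here, no measured step bears on this change, and every value of the series sits at a limit, so the step that the limit leaves unreadable from compound 3 to compound 4 is expected to be no readable effect within the range of this assay. Compound 4 is therefore expected to give about 26000 nM in this assay, with a range from 10000 nM to 60000 nM, most likely again reported as a limit.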

Compound 4, half-maximal effective concentration: > 26000 nM
Compound 4 gave a limit, no number; the forecaster's own chance of this, stated with the estimate: 85%; the middle value lies on the limit itself.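

The steps from compound 1, compound 2 and compound 3 to compound 4 cannot be read in size or direction, as all four compounds stand at limits. The compounds shown leave open whether any group at this place gives a measurable effect in this assay.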